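Pyridin-4-yl in place of 4-cyanophenyl on a carbonyl carbon

The source may hold more compounds than are shown below. What is called first, only, known or untested is meant among the compounds shown, and "the series" means these compounds.

Of the compounds shown here, two with the same core have been read so far in a toxicity assay on THP-1 cells (Homo sapiens) for inhibition; on this read-out lower numbers stand for higher toxicity in this test and higher numbers for lower toxicity in this test. Compound 1 (`COc1ccc(-c2cnc(NC(=O)c3cccnc3)n2C)cc1`) gives > 100000 nM, which is a limit of the assay. Compound 2 (`COc1ccc(-c2cnc(NC(=O)c3ccc(C#N)cc3)n2C)cc1`) gives > 100000 nM, which is also a limit, so only a limit marks where compound 2 stands. The picture so far is the limit of > 100000 nM in this assay, at which 2 of the 2 values shown sit. Going by the values given here, the one measured step is a step that the two limits leave unreadable from compound 1 to compound 2, and it offers no size to carry forward.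

Compound 3 (`COc1ccc(-c2cnc(NC(=O)c3ccncc3)n2C)cc1`) differs from compound 2 as follows: pyridin-4-yl in place of 4-cyanophenyl on a carbonyl carbon. The measured step concerns the same carbonyl carbon as this change. That step gives only limits. Compound 1, with pyridin-3-yl at that place, gives > 100000 nM, again a limit, so no step beyond the scatter is expected and no direction can be given. The expected size of the change is a number no higher from compound 2 to compound 3 (the limit leaves the size open). In this assay the estimate for compound 3 is 100000 nM, with an expected range from 40000 nM to 200000 nM. A report of only a limit is the likeliest expected outcome.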

Compound 3, half-maximal cytotoxic concentration: > 100000 nM
Compound 3 gave a limit, no number (the forecaster's own chance of this, stated with the estimate: 85%); the middle value lies on the limit itself.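

In this assay compound 3 gives > 100000 nM, a limit of the assay. No step among compound 1, compound 2 and compound 3 can be read: the limit of > 100000 nM in this assay, at which 3 of the 3 values shown sit.

The compounds shown leave open whether any group on the carbonyl carbon gives a measurable number in this assay, and how large such a step would be.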